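From Pyridin-4-yl to 1,3-Thiazol-5-yl: An Expected Potency

The compounds below may be only part of what the source reports. "The series", "measured", "known", "first", "only" and "open" are said of these compounds alone.

Three measured compounds share one core and differ only in the aromatic ring attached to the chlorinated benzene. Compound 1 `Cn1nc2c(=O)n(CC3(O)CCN(Cc4ccc(-c5ccoc5)cc4Cl)CC3)cnc2c1-c1ccc(CN)cc1` carries a furan-3-yl, and in an assay on isolated protein for inhibition of ubiquitin carboxyl-terminal hydrolase 7 (Homo sapiens), with stated times of 30 min and 2 h (on this read-out higher numbers stand for weaker inhibition and lower numbers for stronger inhibition), compound 1 gives 177 nM. Compound 2 `Cn1nc2c(=O)n(CC3(O)CCN(Cc4ccc(-c5cccs5)cc4Cl)CC3)cnc2c1-c1ccc(CN)cc1` carries a thiophen-2-yl, and in this assay compound 2 gives 38.6 nM. Compound 3 `Cn1nc2c(=O)n(CC3(O)CCN(Cc4ccc(-c5ccncc5)cc4Cl)CC3)cnc2c1-c1ccc(CN)cc1` carries a pyridin-4-yl, and in this assay compound 3 gives 257 nM, the highest of the three numbers. One of its two steps lies within the scatter, a 1.5-fold higher number from compound 1 to compound 3 (0.16 log units; within the scatter), while the other lies beyond it, a 6.7-fold higher number from compound 2 to compound 3 (0.82 log units; beyond the scatter).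

Compound 4 `Cn1nc2c(=O)n(CC3(O)CCN(Cc4ccc(-c5cncs5)cc4Cl)CC3)cnc2c1-c1ccc(CN)cc1` has not yet been measured. The change is 1,3-thiazol-5-yl in place of pyridin-4-yl on an aromatic carbon. The incoming ring is five-membered and holds sulfur, as the ring in compound 2 does, yet it also keeps a ring nitrogen, as compound 3 does. The step that bears most directly is a 6.7-fold higher number from compound 2 to compound 3 (0.82 log units; beyond the scatter), where the five-membered sulfur ring went with the lower number; a 1.5-fold higher number from compound 1 to compound 3 (0.16 log units; within the scatter) shows that a five-membered ring alone does not always move the number beyond the scatter. Because a 6.7-fold higher number from compound 2 to compound 3 (0.82 log units; beyond the scatter) was beyond the scatter, compound 4 is expected to give a lower number, a modest step of a 2.9-fold lower number from compound 3 to compound 4 (0.46 log units; beyond the scatter). Compound 4 is therefore estimated at 90 nM, within a range from 30 nM to 270 nM.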

Compound 4, half-maximal inhibitory concentration: 117 nM
For compound 4 the middle estimate is 1.3-fold (0.11 log units) below the measured one; the measured number falls inside the stated range.
By their numbers in this assay, from the lowest: compound 2; then compounds 4, 1 and 3 (each within the scatter of the next, the first and the last beyond it).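

Compound 4 shows that a ring nitrogen does not fix the number at this position, para to a large group: replacing the six-membered pyridin-4-yl with the five-membered 1,3-thiazol-5-yl, which also holds a nitrogen, gives a change beyond the usual scatter (a 2.2-fold lower number from compound 3 to compound 4 (0.34 log units; beyond the scatter)). It also shows that a sulfur in a five-membered aromatic ring is not enough to match compound 2, as the two sulfur-bearing rings differ clearly (a 3.0-fold higher number from compound 2 to compound 4 (0.48 log units; beyond the scatter)), and compound 2 keeps the lowest number of the four. The comparison with the furan-3-yl ring gives no such separation (a 1.5-fold lower number from compound 1 to compound 4 (0.18 log units; within the scatter)), so compound 1 and compound 4 cannot be told apart in this measurement, even though only the ring in compound 4 holds sulfur and nitrogen.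

No supporting measurement is available to explain why these rings differ. Still open, going by these compounds, is what a plain phenyl or a thiophen-3-yl ring would give at this position, and how an amine or a carboxylic acid on the thiazole ring would change the number.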